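Methoxy in place of vinyl on the side chain of compound 3

The compounds below may be only part of what the source reports. "The series", "measured", "known", "first", "only" and "open" are said of these compounds alone.

In a functional assay on PC-3 cells (Homo sapiens) for antiproliferative activity (on this read-out higher numbers stand for weaker inhibition and lower numbers for stronger inhibition), compound 1 (`O=C(CCCCCCC(=O)Nc1ccc(Nc2nc(-c3cn[nH]c3)c3cc[nH]c3n2)cc1)NO`) reads 20100 nM and compound 2 (`CCCn1cc(-c2nc(Nc3ccc(NC(=O)CCCCCCC(=O)NO)cc3)nc3[nH]ccc23)cn1`) reads 13400 nM while compound 3 (`C=CCCn1cc(-c2nc(Nc3ccc(NC(=O)CCCCCCC(=O)NO)cc3)nc3[nH]ccc23)cn1`) reads 7700 nM in this set. The standing of compound 3 rests on two steps (a 1.7-fold lower number from compound 2 to compound 3 (0.24 log units; within the scatter)) and (a 2.6-fold lower number from compound 1 to compound 3 (0.42 log units; beyond the scatter)). Compound 4 (`COCCn1cc(-c2nc(Nc3ccc(NC(=O)CCCCCCC(=O)NO)cc3)nc3[nH]ccc23)cn1`) has methoxy in place of vinyl on a saturated chain carbon, two bonds along the chain from an aromatic nitrogen. Within the data shown here, no measured step puts methoxy there. Among the measured compounds shown here, the one measured change at this carbon (a 1.7-fold lower number from compound 2 to compound 3 (0.24 log units; within the scatter)) is small, and the propyl step (a 1.5-fold lower number from compound 1 to compound 2 (0.18 log units; within the scatter)) is small too. No step beyond the scatter is therefore expected in this assay (estimated as a 1.3-fold higher number from compound 3 to compound 4 (0.11 log units; within the scatter)). For compound 4 the estimate is 10000 nM (expected range 5000 nM to 20000 nM).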

Compound 4, half-maximal inhibitory concentration: 35000 nM
The estimate for compound 4 lay 3.5-fold (0.54 log units) below the measured number; the measured number lies above the stated range.
By their numbers in this assay, from the lowest: compounds 3, 2, 1 and 4 (each within the scatter of the next, the first and the last beyond it).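

In this assay, this chain carbon proves sensitive to the group it carries: methoxy in place of vinyl gives a step beyond the scatter (a 4.5-fold higher number from compound 3 to compound 4 (0.66 log units; beyond the scatter)), and methoxy in place of methyl does too (a 2.6-fold higher number from compound 2 to compound 4 (0.42 log units; beyond the scatter)). With 2-methoxyethyl on the aromatic nitrogen, compound 4 stays within the scatter of the unsubstituted compound 1 (a 1.7-fold higher number from compound 1 to compound 4 (0.24 log units; within the scatter)), so a chain at this nitrogen does not by itself bring a lower number. Nothing available accounts for the difference between methoxy and vinyl at this carbon.

Open, from the compounds shown here alone, is whether a terminal amine, a carboxylic acid or a longer ether chain would read closer to compound 3 or to compound 4. With so few groups at this carbon, no trend can yet be drawn.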